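The compounds below may be only part of what the source reports. "The series", "measured", "known", "first", "only" and "open" are said of these compounds alone.

Compound 2 `CCN1CCN(c2nc(C)c3cc(NC(=O)COc4ccc(Cl)cc4)ccc3n2)CC1` is tested in an assay on CHO-K1 cells for displacement of a labelled ligand from melanin-concentrating hormone receptor 1 (Homo sapiens), with a stated time of 2 h (on this read-out higher numbers stand for weaker inhibition and lower numbers for stronger inhibition), where compound 2 gives 690 nM, the highest of the three numbers available. Compound 1 `Cc1nc(N2CCN(C(=O)C3CCC3)CC2)nc2ccc(NC(=O)COc3ccc(OC(F)(F)F)cc3)cc12` gives 84 nM and compound 3 `Cc1nc(N2CCN(C(=O)C3CC3)CC2)nc2ccc(NC(=O)COc3ccc(OC(F)(F)F)cc3)cc12` gives 49 nM; both differ from compound 2 in more than one place, so neither offers a single-change comparison. Compound 4 `Cc1nc(N2CCN(C3CCCC3)CC2)nc2ccc(NC(=O)COc3ccc(Cl)cc3)cc12` arises from compound 2 by one change: cyclopentyl in place of ethyl on an amine nitrogen in a ring. Among the measured compounds shown here, the only measured single-change step, a 1.7-fold lower number from compound 1 to compound 3 (0.23 log units; within the scatter), concerns cyclopropyl in place of cyclobutyl on a carbonyl carbon and stays within the scatter; it does not touch the amine nitrogen in a ring. With no direct guide, a modest drop in the number is expected, a 2.8-fold lower number from compound 2 to compound 4 (0.44 log units; beyond the scatter). Compound 4 is therefore estimated at 250 nM, within a range from 70 nM to 900 nM.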

Compound 4, half-maximal inhibitory concentration: 96 nM
The estimate for compound 4 lay 2.6-fold (0.42 log units) above the measured number; the range from low to high includes it.
By their numbers in this assay, from the lowest: compounds 3, 1 and 4 (each within the scatter of the next); then compound 2.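

In this assay, the group on this amine nitrogen in a ring clearly matters: cyclopentyl in place of ethyl gives a 7.2-fold lower number from compound 2 to compound 4 (0.86 log units; beyond the scatter). The larger group, which brings a five-membered ring of carbon only, is accepted here and goes with stronger inhibition. No measurement available here explains the change.

Going by these compounds, only these two groups on this nitrogen can be compared directly, so it stays open whether the ring or simply the added carbon counts. An open pentyl chain or a cyclohexyl ring here would help to separate the two.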